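Compound 4: propanoylamino in place of chloro

A few compounds are considered here, and "the series" means these few. Any claim that something is new, unique, unknown or untested is made for them only; others in the source may bear on it.

compound 1 (`CC(C)Oc1ccc(C(=O)Nc2ccc(N(C)C)cc2)cc1NC(=O)C(C)Br`) gives 7900 nM
compound 2 (`CCC(=O)Nc1cc(C(=O)Nc2ccc(N3CCN(C)CC3)cc2)ccc1OC`) gives > 200000 nM (a limit, not a number)
compound 3 (`CN1CCN(Cc2ccc(NC(=O)c3ccc(OCCCCl)c(Cl)c3)cc2C(F)(F)F)CC1`) gives 4100 nM

All three readings come from a toxicity assay on Huh-7.5 cells (Homo sapiens) for inhibition, read by MTT assay, with a stated time of 96 h; on this read-out higher numbers stand for lower toxicity in this test and lower numbers for higher toxicity in this test. Compound 3 (4100 nM) lies within the scatter of compound 1 (7900 nM), so no order can be drawn between them. The reading of compound 2 (> 200000 nM) is a limit of the assay and not a number.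

Compound 4 (`CCC(=O)Nc1cc(C(=O)Nc2ccc(CN3CCN(C)CC3)c(C(F)(F)F)c2)ccc1OCCCCl`) is compound 3 with a single change (propanoylamino in place of chloro on an aromatic carbon). Propanoylamino stands in place of chloro on an aromatic carbon, ortho to a 3-chloropropoxy group and meta to a large group. Among the compounds with values here, no measured pair isolates this change. Within the data shown here, the only guide is compound 2, which also carries propanoylamino and sits at a limit (> 200000 nM). Compound 2 differs from compound 4 in other places too, so it supports a direction only weakly. Compound 4 keeps everything else of compound 3 (4100 nM), so a jump to the reading of compound 2 is not expected. In this assay a moderate move towards a higher number, meaning lower toxicity, is expected, and the estimated step is a 2.9-fold higher number from compound 3 to compound 4 (0.47 log units; beyond the scatter). The estimate for compound 4 is 12000 nM, with an expected range from 3500 nM to 45000 nM.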

Compound 4, half-maximal cytotoxic concentration: 7870 nM
The estimate for compound 4 lay 1.5-fold (0.18 log units) above the measured number; the measured number falls inside the stated range.
By their numbers in this assay, from the lowest: compounds 3, 4 and 1 (each within the scatter of the next). At a limit, above all of these: compound 2.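

Working notes on this position: in this assay, propanoylamino in place of chloro on the aromatic carbon ortho to the 3-chloropropoxy group gives a 1.9-fold higher number from compound 3 to compound 4 (0.28 log units; within the scatter), the first reading in the series that isolates this change. Here, a group of 5 heavy atoms with 1 hydrogen-bond donor and 1 hydrogen-bond acceptor replaces a single chlorine, yet no order can be drawn between compound 3 and compound 4 in this assay. Compound 2 differs from compound 4 in more than one place, so its reading, which is a limit and not a number, says nothing about this change: the limit of > 200000 nM in this assay, at which 1 of the 4 values shown sits.

Still open, going by these compounds, is whether an amine, a carboxylic acid or a longer acyl chain on this aromatic carbon would also stay within the scatter of compound 3 or would move the reading beyond it in this assay. Within the data shown here, also open is whether propanoylamino in place of chloro would give a similar step with a methoxy group in place of the 3-chloropropoxy group, as the series holds no second pair for this change.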